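Aryl swap on the pyridine core, Vero cell tolerance

This account rests on a few compounds, and the source may have more. Where it says the series, first, only, none or still open, it means among the compounds named here.

compound 1 `COc1nc(-c2ccccc2F)ccc1[C@@H](c1ccccc1)[C@@](O)(CCN(C)C)c1cccc2ccccc12` — > 50 ug/mL
compound 2 `COc1ncc(-c2ccccc2)cc1[C@@H](c1ccccc1)[C@@](O)(CCN(C)C)c1ccccc1` — > 50 ug/mL
compound 3 `COc1ncc(-c2ccccc2)cc1[C@@H](c1ccccc1)[C@@](O)(CCN(C)C)c1cccc(F)c1F` — > 50 ug/mL

All three measured compounds were tested in a toxicity assay on Vero cells (Chlorocebus sabaeus) for cytotoxicity; a lower number here means that less compound is tolerated, a higher number that more compound is tolerated. Compound 1 gives > 50 ug/mL, which is a limit of the assay and not a number. Compound 2 likewise gives > 50 ug/mL, again a limit. Compound 3 gives > 50 ug/mL, also a limit. So no measured compound has a number at all; all that is known is the limit of > 50 ug/mL in this assay, at which 3 of the 3 values shown sit. Within the data shown here, the only step between two compounds that differ in one place, a step that the two limits leave unreadable from compound 2 to compound 3, is therefore unreadable, and compound 1 stands at the same limit as the other two.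

Compound 4 `COc1nc(-c2ccc(Cl)c(F)c2)ccc1[C@@H](c1ccccc1)[C@@](O)(CCN(C)C)c1cccc2ccccc12` differs from compound 1 by 4-chloro-3-fluorophenyl in place of 2-fluorophenyl on an aromatic carbon. Among the measured compounds shown here, no measured step bears on this change, and the one step that exists gives no size. The expectation for compound 4 therefore rests only on the three limits: compound 4 is expected to come out at 50 ug/mL in this assay, within a range of 25 ug/mL to 100 ug/mL, and most likely again as a limit. The step of a number no higher from compound 1 to compound 4 (the limit leaves the size open) is expected to be none beyond the scatter.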

Compound 4, half-maximal cytotoxic concentration: > 50 ug/mL
Compound 4: only a limit was reported; the forecaster's own chance of this, stated with the estimate: 80%; the middle value lies on the limit itself.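

In this assay compound 4 gives > 50 ug/mL, which is a limit of the assay and not a number. Compound 1 also sits at a limit, so no step between compound 1 and compound 4 can be read: the limit of > 50 ug/mL in this assay, at which 4 of the 4 values shown sit.

The compounds shown leave open at what concentration, if any within reach, each one harms these cells, and whether swapping an aryl group changes that.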